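Compound 3: cyclobutyl in place of propyl

This account rests on a few compounds, and the source may have more. Where it says the series, first, only, none or still open, it means among the compounds named here.

Among the measured compounds shown here, in a physicochemical assay for solubility, in phosphate buffer, at pH 6.8 (a higher number here means a more soluble compound, a lower number a less soluble compound), compound 2 `CCCNc1nc2ccsc2c(=O)n1CC` gives 69 ug/mL, the higher of the two numbers so far, and compound 1 `CCn1c(NC(C)(C)C)nc2ccsc2c1=O` gives 3.7 ug/mL. Compound 3 `CCn1c(NC2CCC2)nc2ccsc2c1=O` has cyclobutyl in place of propyl on a nitrogen on an aromatic ring. For the measured compounds named here, only one measured step bears on this place, the large 19-fold higher number from compound 1 to compound 2 (1.27 log units; beyond the scatter), with propyl in place of tert-butyl. With that single step as the guide, a moderate fall in this assay is expected, smaller than that step: a 3.1-fold lower number from compound 2 to compound 3 (0.50 log units; beyond the scatter). For compound 3 the estimate is 22 ug/mL, with an expected range of 7 ug/mL to 65 ug/mL.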

Compound 3, solubility: 6.3 ug/mL
Compound 3: the middle estimate sits 3.5-fold (0.54 log units) above what was measured, outside the stated range (below it).
By their numbers in this assay, from the lowest: compounds 1 and 3 (each within the scatter of the next); then compound 2.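

In this assay, with the substituent on a nitrogen on an aromatic ring, adding the ring of cyclobutyl in place of propyl gives an 11-fold lower number from compound 2 to compound 3 (1.04 log units; beyond the scatter), so the earlier propyl advantage over tert-butyl does not extend to cyclobutyl. Cyclobutyl in place of tert-butyl gives a 1.7-fold higher number from compound 1 to compound 3 (0.23 log units; within the scatter), which leaves compound 2 alone apart from the other two compounds. No evidence accounts for this split.

Open, from the compounds shown here alone, is whether a longer chain such as butyl stays with propyl, and how a hydroxyethyl group or a carboxylic acid at this nitrogen would read.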